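Methyl in Place of Fluoro: What to Expect for Compound 4

The source may report more compounds than this note shows. Statements on the series, on what has been measured and on what is new or still open speak of the compounds shown alone.

Three compounds have been measured in a functional assay on A549 cells (Homo sapiens) for antiproliferative activity, read by MTT assay, with a stated time of 72 h; a higher number here means a weaker inhibitor, a lower number a stronger inhibitor:

Compound 1 `NS(=O)(=O)c1ccc(NC(=S)Nc2ccc3ncnc(Nc4cccc(C(F)(F)F)c4)c3c2)cc1`: 10100 nM
Compound 2 `NS(=O)(=O)c1ccc(NC(=S)Nc2ccc3ncnc(Nc4cccc(Br)c4)c3c2)cc1`: 25000 nM
Compound 3 `NS(=O)(=O)c1ccc(NC(=S)Nc2ccc3ncnc(Nc4cccc(F)c4)c3c2)cc1`: 25900 nM

Compound 3 gives the highest of the three numbers. Its value sits within the scatter of compound 2, as the step of a 1.0-fold higher number from compound 2 to compound 3 (0.02 log units; within the scatter) shows, while compound 1 is clearly lower, by the step of a 2.6-fold higher number from compound 1 to compound 3 (0.41 log units; beyond the scatter). The step of a 2.5-fold higher number from compound 1 to compound 2 (0.39 log units; beyond the scatter) matches that picture: the trifluoromethyl compound stands apart, and the bromo and fluoro compounds sit together.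

Compound 4 `Cc1cccc(Nc2ncnc3ccc(NC(=S)Nc4ccc(S(N)(=O)=O)cc4)cc23)c1` differs from compound 3 by methyl in place of fluoro on an aromatic carbon. Within the data shown here, no measured step exchanges fluoro for methyl, so the expectation rests on what the three steps show about this position. The swap of bromo for fluoro, a 1.0-fold higher number from compound 2 to compound 3 (0.02 log units; within the scatter), left the number within the scatter, and only trifluoromethyl moved it, by a 2.5-fold higher number from compound 1 to compound 2 (0.39 log units; beyond the scatter) and a 2.6-fold higher number from compound 1 to compound 3 (0.41 log units; beyond the scatter). Methyl is therefore expected to behave more like fluoro and bromo than like trifluoromethyl, with a step from compound 3 to compound 4 of a 1.3-fold lower number from compound 3 to compound 4 (0.11 log units; within the scatter), which is not expected to go beyond the scatter. Compound 4 is estimated at 20000 nM, with a range from 8000 nM to 50000 nM.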

Compound 4, half-maximal inhibitory concentration: > 40000 nM
Compound 4: only a limit was reported; the forecaster's own chance of this, stated with the estimate: 10%; middle value at least 2.0-fold (0.30 log units) away from the limit.
By their numbers in this assay, from the lowest: compound 1; then compounds 2 and 3 (each within the scatter of the next). At a limit, above all of these: compound 4.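

In this assay compound 4 gives a limit and not a number: the limit of > 40000 nM in this assay, at which 1 of the 4 values shown sits.

Set against trifluoromethyl, the change can still be read, with a step of an at least 3.9-fold higher number from compound 1 to compound 4 (0.59 log units; beyond the scatter); compound 1 therefore stands apart from the methyl compound, just as it stands apart from the bromo and fluoro compounds. Set against the two halogens, the floors of an at least 1.5-fold higher number from compound 3 to compound 4 (0.18 log units; that floor lies within the scatter) and an at least 1.6-fold higher number from compound 2 to compound 4 (0.20 log units; that floor lies within the scatter) lie within the scatter, so the true size of either step remains unknown, and the one thing the result adds is that methyl on this aromatic carbon does not bring the number towards that of compound 1.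

The compounds shown leave open how far above its limit compound 4 lies, and so whether methyl truly differs from fluoro and bromo here. They also leave open whether the standing of compound 1 belongs to trifluoromethyl alone, or would be shared by a nitrile, a methoxy group or an amine on the same aromatic carbon.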